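The source may report more compounds than this note shows. Statements on the series, on what has been measured and on what is new or still open speak of the compounds shown alone.

Series notes. Two compounds carry numbers in an assay on HEK293 cells for positive allosteric modulation of metabotropic glutamate receptor 3 (Rattus norvegicus), read by thallium flux, with a stated time of 2.5 min; a higher number here means a larger maximal response, a lower number a smaller maximal response. Compound 1 `COc1ccc(C(=O)O)cc1OCCCCOc1ccc(C(=O)C(C)C)c(O)c1C` gives 59.9% in this assay. Compound 2 `Cc1c(OCCCCOc2cccc(C(=O)O)c2)ccc(C(=O)CC2CCCC2)c1O` gives 92.9% in this assay. Compound 1 thus stands lowest of the two, with compound 2 higher by a margin beyond the usual scatter; the two structures differ in more than one place, so nothing is taken from that pair beyond what the two values show.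

Compound 3 `COc1ccc(C(=O)O)cc1OCCCCOc1ccc(C(C)=O)c(O)c1C` is not yet measured. It differs from compound 1 by methyl in place of isopropyl on a carbonyl carbon: isopropyl leaves and methyl enters on a carbonyl carbon whose other neighbour is an aromatic carbon, so that isopropylcarbonyl reads as acetyl. Within the data shown here, no single-point step between measured compounds is available to rate this change. The step expected from compound 1 to compound 3 in this assay, a number 4.9 percentage points lower from compound 1 to compound 3 (within the scatter), is none beyond the scatter, leaning slightly downward. Compound 3 is expected to give 55% in this assay, within 35% to 75%.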

Compound 3, largest response reached (reported as percent of maximum), in percent of the reference or control that the assay uses: 34.8%
The estimate for compound 3 lay 20.2 percentage points above the measured number; measured number outside the range, below it.
By their numbers in this assay, from the lowest: compound 3; then compound 1; then compound 2.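

At the carbonyl carbon whose other neighbour is an aromatic carbon, the group is not a silent choice in this assay: methyl in place of isopropyl gives a number 25.1 percentage points lower from compound 1 to compound 3 (beyond the scatter). Among these compounds, this is the first single-place step, and it shows that the maximal response depends on what sits on this carbonyl carbon, with isopropylcarbonyl ahead of acetyl on the core of compound 1. Nothing measured speaks to the reason for this step.

One step cannot show whether the response follows the size of this group or is specific to isopropyl, and an ethyl, a cyclopropyl or a tert-butyl on the same carbonyl carbon would separate those readings. Compound 2 also differs here, but it differs in more than one place and so does not settle the question.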